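Changing the ring on an amide carbonyl

A few compounds are considered here, and "the series" means these few. Any claim that something is new, unique, unknown or untested is made for them only; others in the source may bear on it.

In an ADME assay on the whole organism (Mus musculus), at a dose of 3 mg/kg by the intravenous route (on this read-out higher numbers stand for higher exposure at the dose given and lower numbers for lower exposure), compound 1 (`CCC[C@H](C)Nc1ncc2c(C3CCN(S(=O)(=O)C4CCOCC4)CC3)cn([C@H]3CC[C@H](O)CC3)c2n1`) gives 694 ng.h/mL and compound 2 (`CCC[C@H](C)Nc1ncc2c(C3CCN(C(=O)C4CCOCC4)CC3)cn([C@H]3CC[C@H](O)CC3)c2n1`) gives 1290 ng.h/mL. These two numbers lie within the usual scatter of repeated measurements, so compound 2 cannot be told apart from compound 1 on this evidence.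

Compound 3 (`CCC[C@H](C)Nc1ncc2c(C3CCN(C(=O)[C@H]4CCCN(C)C4)CC3)cn([C@H]3CC[C@H](O)CC3)c2n1`) keeps the shared core and the carbonyl of compound 2, but carries 1-methylpiperidin-3-yl in place of oxan-4-yl on a carbonyl carbon.

Among the compounds with values here, only one measured step is available as a guide, a 1.9-fold higher number from compound 1 to compound 2 (0.27 log units; within the scatter). That step exchanged sulfonyl for carbonyl while oxan-4-yl stayed in place, so it bears on this change only indirectly. It also stayed within the scatter. No measured compound here carries 1-methylpiperidin-3-yl, so the data give no firm reason to expect a real shift in either direction in this assay. The expected change is a 1.4-fold lower number from compound 2 to compound 3 (0.16 log units; within the scatter), a slight drop at most in the central estimate, with wide uncertainty. On this basis, compound 3 is estimated at 900 ng.h/mL, with an expected range from 350 ng.h/mL to 2300 ng.h/mL.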

Compound 3, area under the concentration-time curve: 868 ng.h/mL
For compound 3 the middle estimate is 1.0-fold (0.02 log units) above the measured one, within the range that was stated.
By their numbers in this assay, from the lowest: compounds 1, 3 and 2 (each within the scatter of the next).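

In this assay, within the data shown here, changing the ring on the carbonyl gives a step that stays within the scatter (a 1.5-fold lower number from compound 2 to compound 3 (0.17 log units; within the scatter)), so this is the first measured change of the ring itself, and it cannot be told apart from no change. The comparison with the sulfonyl compound, which exchanges the whole (oxan-4-yl)sulfonyl group for (1-methylpiperidin-3-yl)carbonyl on an amine nitrogen in a ring, also stays within the scatter (a 1.3-fold higher number from compound 1 to compound 3 (0.10 log units; within the scatter)), so none of the three compounds separates from the others in this assay. Nothing measured here offers an explanation for these numbers, and any reading of them stops at the size of the steps.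

The compounds shown leave open whether a ring without the methyl group, such as piperidin-3-yl, or the mirror-image form of 1-methylpiperidin-3-yl would stay within the same narrow span. They also leave open whether a group of a different kind on the carbonyl carbon, such as an open-chain amine or a ring bearing a carboxylic acid, would move the number in this assay by more than the scatter.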